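Fluorines in Place of Chlorines on a Limit-Bound Compound

The compounds below may be only part of what the source reports. "The series", "measured", "known", "first", "only" and "open" are said of these compounds alone.

Compound 1 `COc1ccc(-c2cc(/C=C/C(=O)c3ccc(N)cc3)[nH]n2)cc1`: in a functional assay on NCI-H23 cells (Homo sapiens) for inhibition, read by sulforhodamine B assay, with a stated time of 48 h (on this read-out higher numbers stand for lower toxicity in this test and lower numbers for higher toxicity in this test), compound 1 gives 68400 nM.
Compound 2 `COc1cc(-c2cc(/C=C/C(=O)c3ccc(Cl)c(Cl)c3)[nH]n2)cc(OC)c1OC`: in this assay compound 2 is reported only as the limit > 100000 nM.
Compound 3 `COc1ccc(C(=O)/C=C/c2cc(-c3cc(OC)c(OC)c(OC)c3)n[nH]2)cc1`: in this assay compound 3 is likewise reported only as the limit > 100000 nM.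

Compound 2 therefore stands not at a number but at the limit of > 100000 nM in this assay, at which 2 of the 3 values shown sit, and it shares that position with compound 3. For the measured compounds named here, the one measured step that starts from compound 2, a step that the two limits leave unreadable from compound 2 to compound 3, is unreadable, since both of its ends are limits; all that can be said is that neither compound reached a measurable value.

Compound 4 `COc1cc(-c2cc(/C=C/C(=O)c3ccc(F)c(F)c3)[nH]n2)cc(OC)c1OC` is the next compound to be measured. It differs from compound 2 in a single place: 3,4-difluorophenyl in place of 3,4-dichlorophenyl on a carbonyl carbon.

Going by the values given here, no measured step bears on an exchange of chlorine for fluorine, and the only step from compound 2, a step that the two limits leave unreadable from compound 2 to compound 3, gives no size to lean on. Since compound 2 sits at the limit, the expectation for compound 4 in this assay is a step of a number no higher from compound 2 to compound 4 (the limit leaves the size open) of no size beyond the scatter. Compound 4 is therefore estimated at 100000 nM, with a range from 40000 nM to 300000 nM, and it is quite likely to be reported again only as a limit.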

Compound 4, concentration lethal to 50% of the cells: > 100000 nM
Compound 4: a limit, no number; the forecaster's own chance of this, stated with the estimate: 65%; the middle value sits exactly at the limit.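

Compound 4 is reported in this assay only as the limit > 100000 nM. The steps to compound 4 from compound 2 and from compound 3 cannot be read, and all three compounds stand at the same place: the limit of > 100000 nM in this assay, at which 3 of the 4 values shown sit.

The compounds shown leave open how far these three compounds lie from one another in this assay.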